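Replacing 4-Bromophenyl with 1-Phenylethyl on the Ring Nitrogen

The source may hold more compounds than are shown below. What is called first, only, known or untested is meant among the compounds shown, and "the series" means these compounds.

Measured so far:
compound 1 `CCCn1c(=O)[nH]c2nc(-c3ccc(S(=O)(=O)N4CCN(c5ccc(F)cc5)CC4)cc3)[nH]c2c1=O` gives 14%;
compound 2 `CCCn1c(=O)[nH]c2nc(-c3ccc(S(=O)(=O)N4CCN(c5ccc(Br)cc5)CC4)cc3)[nH]c2c1=O` gives 13%;
compound 3 `CCCn1c(=O)[nH]c2nc(-c3ccc(S(=O)(=O)N4CCN(c5cccc(Cl)c5)CC4)cc3)[nH]c2c1=O` gives 21%.

These three compounds share one core and differ only in the aromatic group attached to the amine nitrogen in the ring. In an assay on CHO cells for displacement of a labelled ligand from adenosine receptor A1 (Homo sapiens), read by scintillation counting, with a stated time of 90 min, tested at 1 uM, in the presence of a further agent that is not named here (a higher number here means more inhibition at the concentration tested (going by the name of the read-out), a lower number less inhibition), compound 2 gives 13%, the lowest of the three numbers, but both neighbours sit close to it: the step of a number 1 percentage points lower from compound 1 to compound 2 (within the scatter) and the step of a number 8 percentage points higher from compound 2 to compound 3 (within the scatter) are each within the usual scatter, so no real ordering can be claimed among the three.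

The next compound, compound 4 `CCCn1c(=O)[nH]c2nc(-c3ccc(S(=O)(=O)N4CCN(C(C)c5ccccc5)CC4)cc3)[nH]c2c1=O`, is made from compound 2 by the change (1-phenylethyl in place of 4-bromophenyl on an amine nitrogen in a ring). Among the compounds with values here, none of the measured steps exchanges an aromatic group for one carrying a saturated carbon between the nitrogen and the benzene ring, so the measured steps only show that changing the halogen or its position (a number 1 percentage points lower from compound 1 to compound 2 (within the scatter), a number 7 percentage points higher from compound 1 to compound 3 (within the scatter)) leaves the result inside the scatter. On that basis no step beyond the scatter in this assay is expected from this change either. Compound 4 is therefore estimated at 18%, within a range of 4% to 36%, corresponding to an expected step of a number 5 percentage points higher from compound 2 to compound 4 (within the scatter).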

Compound 4, a percentage reported as inhibition, at one concentration (the size of the read-out at that concentration, not a potency): 42%
Compound 4: middle estimate off by 24 percentage points, on the low side, and the stated range ends below it.
By their numbers in this assay, from the lowest: compounds 2, 1 and 3 (each within the scatter of the next); then compound 4.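

In this assay, this position on the amine nitrogen in a ring turns out to respond to a change of group: 1-phenylethyl gives a number 29 percentage points higher from compound 2 to compound 4 (beyond the scatter), a number 28 percentage points higher from compound 1 to compound 4 (beyond the scatter) and a number 21 percentage points higher from compound 3 to compound 4 (beyond the scatter), so compound 4 stands clear of all three halogen-bearing compounds, which could not be told apart from one another. The change alters two things at once, since 1-phenylethyl carries no halogen and its benzene ring is joined to the nitrogen through a saturated carbon bearing a methyl, whereas the three phenyl groups it is compared with are bonded to the nitrogen directly, so the higher number cannot be assigned to either feature alone. Nothing available here explains why this group raises the number.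

The compounds shown leave open which of the two features matters, and an unsubstituted phenyl and a benzyl group on the same nitrogen would begin to separate them. They also leave open whether a longer chain, such as 2-phenylethyl, would keep the higher number or lose it.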